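Replacing an aryl group with isobutyl on the lactam nitrogen

The compounds below may be only part of what the source reports. "The series", "measured", "known", "first", "only" and "open" are said of these compounds alone.

Compound 1 `O=C1CC(c2nc(-c3cccc(Cl)c3)no2)CN1c1ccc(Cl)cc1`: > 10000 nM
Compound 2 `C[C@H](c1ccccc1)N1C[C@H](c2nc(-c3cccc(Cl)c3)no2)CC1=O`: 1600 nM
Compound 3 `O=C1CC(c2nc(-c3cccc(Cl)c3)no2)CN1c1ccccc1Cl`: 680 nM

The three measured compounds share a core and differ only in the group on the amide-type nitrogen in the ring. In an in vitro functional assay on HEK293-A cells for negative allosteric modulation of metabotropic glutamate receptor 5 (Homo sapiens), read by FLIPR and calcium flux (on this read-out higher numbers stand for weaker inhibition and lower numbers for stronger inhibition), compound 1 reaches only the limit of > 10000 nM in this assay, at which 1 of the 3 values shown sits, and no number. Compound 2 gives 1600 nM in this assay, and compound 3 gives 680 nM; compound 3 thus has the lowest of the two numbers, with compound 2 next, the gap between them lying beyond the scatter. Going by the values given here, the one step between measured compounds, an at least 14-fold lower number from compound 1 to compound 3 (1.16 log units; beyond the scatter), concerns the position of chlorine on an aryl group and not the exchange of aryl for alkyl.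

Compound 4 `CC(C)CN1CC(c2nc(-c3cccc(Cl)c3)no2)CC1=O` is not yet measured. It differs from compound 3 in isobutyl in place of 2-chlorophenyl on an amide-type nitrogen in a ring. Among the compounds with values here, no measured step covers this change directly; compound 2, which carries a non-aryl group on that nitrogen, gives 1600 nM, a higher number than compound 3. Compound 4 is therefore expected to show a higher number, by a step of a 7.4-fold higher number from compound 3 to compound 4 (0.87 log units; beyond the scatter), with real uncertainty about whether a number is reached at all. The estimate for compound 4 is 5000 nM, within 1500 nM to 20000 nM.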

Compound 4, half-maximal inhibitory concentration: 920 nM
Compound 4: middle estimate off by 5.4-fold (0.74 log units), on the high side, and the stated range ends above it.
By their numbers in this assay, from the lowest: compounds 3, 4 and 2 (each within the scatter of the next, the first and the last beyond it). At a limit, above all of these: compound 1.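

In this assay, the step on the amide-type nitrogen in the ring is a 1.4-fold higher number from compound 3 to compound 4 (0.13 log units; within the scatter), so at this position isobutyl, with no ring, and 2-chlorophenyl cannot be told apart, and among the compounds shown an aryl group is not needed to reach a measured number. Isobutyl in place of 4-chlorophenyl gives an at least 10-fold lower number from compound 1 to compound 4 (1.03 log units; beyond the scatter), which shows that the poor result at this position belongs to the 4-chlorophenyl compound and not to every change of the group on this nitrogen. Compound 1 itself remains a limit and not a number: the limit of > 10000 nM in this assay, at which 1 of the 4 values shown sits.

As far as these compounds go, what a cyclohexyl group, a longer chain or a chain ending in an amine would give on this nitrogen stays open. Also open, from the compounds shown here alone, is whether the two mirror-image forms of compound 4 differ in this read-out.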